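A Second Trifluoromethyl Group Added to Compound 1

This account rests on a few compounds, and the source may have more. Where it says the series, first, only, none or still open, it means among the compounds named here.

Measured compounds:
compound 1, `O=C(Nc1cccc(-n2cc(-c3ccncc3)c(-c3ccc(Cl)c(O)c3)n2)c1)Nc1cccc(C(F)(F)F)c1`, 6130 nM
compound 2, `O=C(Nc1cccc(-n2cc(-c3ccncc3)c(-c3ccc(Cl)c(O)c3)n2)c1)Nc1ccc(Cl)c(Cl)c1`, 3150 nM
compound 3, `COc1cc(-c2nn(-c3cccc(NC(=O)Nc4cccc(C(F)(F)F)c4)c3)cc2-c2ccncc2)ccc1Cl`, 1870 nM

All three were tested in a functional assay on OVCAR-3 cells (Homo sapiens) for inhibition, read by sulforhodamine B assay, with a stated time of 48 h; a higher number here means a weaker inhibitor of growth, a lower number a stronger inhibitor of growth. Compound 1 gives 6130 nM, the highest of the three numbers. Compound 2 gives 3150 nM, and the step of a 1.9-fold lower number from compound 1 to compound 2 (0.29 log units; within the scatter) stays within the scatter. Compound 3 gives 1870 nM, and the step of a 3.3-fold lower number from compound 1 to compound 3 (0.52 log units; beyond the scatter) goes beyond the scatter, though it concerns a different part of the molecule.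

Compound 4, `O=C(Nc1cccc(-n2cc(-c3ccncc3)c(-c3ccc(Cl)c(O)c3)n2)c1)Nc1cc(C(F)(F)F)cc(C(F)(F)F)c1`, is not yet measured. It differs from compound 1 by one change: trifluoromethyl in place of hydrogen on an aromatic carbon. Going by the values given here, this is a change on the same outer ring that was exchanged in the step from compound 1 to compound 2, which is the only measured step that bears on it, and that step was within the scatter. The change toward compound 3 sits elsewhere and says little here. A step of no more than the scatter is therefore expected, perhaps a slightly lower number.

Compound 4 is expected to give about 4500 nM in this assay, between 1500 nM and 13000 nM, meaning an estimated step of a 1.4-fold lower number from compound 1 to compound 4 (0.13 log units; within the scatter).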

Compound 4, concentration for total growth inhibition: 1200 nM
The estimate for compound 4 lay 3.8-fold (0.57 log units) above the measured number; measured number outside the range, below it.
By their numbers in this assay, from the lowest: compounds 4, 3, 2 and 1 (each within the scatter of the next, the first and the last beyond it).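

In this assay, placing a second trifluoromethyl group on the outer ring, meta to the trifluoromethyl group already there, gives a 5.1-fold lower number from compound 1 to compound 4 (0.71 log units; beyond the scatter). Going by these compounds alone, this is a modest step, but it shows that this outer ring can shift the number beyond the scatter, which the only earlier change on this ring, a 1.9-fold lower number from compound 1 to compound 2 (0.29 log units; within the scatter), did not show. Nothing measured here explains why the added group has this effect, and no supporting data on its properties or on how the compounds act are available.

With a single substitution of this kind at this position, the compounds shown leave open whether the step belongs to trifluoromethyl itself or whether another group in the same place, such as a nitrile, an amine or a carboxylic acid, would give a similar number. Within the data shown here, they also leave open whether this change and the methyl on the oxygen seen in compound 3 would add up if combined in one molecule, since each has been seen only on its own against compound 1.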